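A few compounds are considered here, and "the series" means these few. Any claim that something is new, unique, unknown or untested is made for them only; others in the source may bear on it.

In an assay on cell membranes from brain for displacement of a labelled ligand from adenosine receptor A1 (Bos taurus) (on this read-out higher numbers stand for weaker inhibition and lower numbers for stronger inhibition), compound 3 `CCCn1c(=O)c2c(nnn2C2CCCC2)n(CCC)c1=O` gives 340 nM, the lowest of the three numbers in hand. Compound 1 `Cn1c(=O)c2c(nnn2C2CCCC2)n(C)c1=O` gives 11000 nM, and compound 2 `Cn1c(=O)c2c(nnn2C2CC3CCC2C3)n(C)c1=O` gives 18000 nM; each of these two numbers stands far beyond the usual scatter from that of compound 3, and each of these two compounds carries methyl groups where compound 3 carries propyl groups. Compound 4 `CCCn1c(=O)c2c(nnn2-c2ccc(Cl)cc2N)n(CCC)c1=O` keeps the propyl groups of compound 3 and alters a single group: 2-amino-4-chlorophenyl in place of cyclopentyl on an aromatic nitrogen. Among the measured compounds shown here, no measured pair here differs in that one place alone, so the size of this step is unknown. Moving away from the cyclopentyl group of compound 3, the number is expected to rise beyond the scatter, a 4.4-fold higher number from compound 3 to compound 4 (0.64 log units; beyond the scatter). In this assay, compound 4 is accordingly estimated at 1500 nM, with a range from 250 nM to 9000 nM.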

Compound 4, inhibition constant: 44000 nM
Beside the measured number, compound 4's estimate is 29-fold (1.47 log units) below it; the whole stated range lies below it.
By their numbers in this assay, from the lowest: compound 3; then compounds 1 and 2 (each within the scatter of the next); then compound 4.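

In this assay, putting 2-amino-4-chlorophenyl in place of cyclopentyl on the aromatic nitrogen gives a 130-fold higher number from compound 3 to compound 4 (2.11 log units; beyond the scatter). Among the compounds shown here, the earlier compounds offered no pair differing in this place alone, so this is the first sign that this position strongly affects the number, and that this change weakens inhibition. Nothing given here explains the size of this step. The compounds shown cannot say whether the aromatic ring, the amino group or the chlorine accounts for it. A plain phenyl group at this position remains an open comparison.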